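The source may report more compounds than this note shows. Statements on the series, on what has been measured and on what is new or still open speak of the compounds shown alone.

Compound 1 `S=c1oc(-c2ccc3c(c2)OCCO3)nn1CN1CCN(c2ccc(Cl)cc2)CC1` is the point of departure. In a functional assay on SW 1116 cells (Homo sapiens) for antiproliferative activity, read by MTT assay, with a stated time of 48 h (a lower number here means a stronger inhibitor, a higher number a weaker inhibitor), compound 1 gives > 50000 nM, which is a limit of the assay rather than a measured number. Of the compounds shown here, two that replace its chloro group have been measured. Compound 2 `COc1ccccc1N1CCN(Cn2nc(-c3ccc4c(c3)OCCO4)oc2=S)CC1` gives 16900 nM in this assay, and compound 3 `COc1ccc(N2CCN(Cn3nc(-c4ccc5c(c4)OCCO5)oc3=S)CC2)cc1` gives 24200 nM. The step of an at least 2.9-fold lower number from compound 1 to compound 2 (0.47 log units; beyond the scatter) and the step of an at least 2.0-fold lower number from compound 1 to compound 3 (0.31 log units; beyond the scatter) both bring the number down, each at least modestly, while a 1.4-fold higher number from compound 2 to compound 3 (0.16 log units; within the scatter) stays within the scatter. Compound 4 `O=[N+]([O-])c1ccc(N2CCN(Cn3nc(-c4ccc5c(c4)OCCO5)oc3=S)CC2)cc1` is not yet measured. It differs from compound 1 in one place: nitro in place of chloro on an aromatic carbon. Among the measured compounds shown here, no measured step exchanges chloro for nitro, so the two methoxy steps bear on it only indirectly: they show that moving away from chloro at this position took the value off its limit, and the evidence the limit of > 50000 nM in this assay, at which 1 of the 3 values shown sits, marks how far compound 1 stands from the measured numbers. A modest downward step is therefore expected in this assay, though the data cannot rule out that compound 4 remains at the limit. Compound 4 is estimated at 30000 nM, with a range from 8000 nM to 100000 nM, which means an expected step of an at least 1.6-fold lower number from compound 1 to compound 4 (0.22 log units; that floor lies within the scatter).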

Compound 4, half-maximal inhibitory concentration: > 50000 nM
Compound 4: no number, only a limit; the forecaster's own chance of this, stated with the estimate: 45%; middle value at least 1.6-fold (0.22 log units) from the limit.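

In this assay compound 4 gives > 50000 nM, which is a limit of the assay and not a number: the limit of > 50000 nM in this assay, at which 2 of the 4 values shown sit. The nitro group therefore does not share the gain seen with methoxy, as shown by an at least 2.0-fold higher number from compound 3 to compound 4 (0.31 log units; beyond the scatter) and by an at least 2.9-fold higher number from compound 2 to compound 4 (0.47 log units; beyond the scatter), so moving away from chloro on this aromatic carbon does not by itself take the value off the limit. The step between compound 1 and compound 4 cannot be read, as both values are limits, and chloro and nitro cannot be told apart in this assay; among the four compounds shown, only the two methoxy compounds, compound 2 and compound 3, give actual numbers.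

As far as these compounds go, how far compound 1 and compound 4 lie beyond the limit stays open, and so does whether a number on this ring is tied to methoxy itself or would also appear with other groups. A hydroxyl, an amine or a methyl group on the same aromatic carbon could separate these possibilities, whereas the four compounds shown cannot.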